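The source may report more compounds than this note shows. Statements on the series, on what has been measured and on what is new or still open speak of the compounds shown alone.

Measured so far:
- compound 1 `O=C(O)/C(S)=C/c1c[nH]c2cc(Br)ccc12`: 90 nM
- compound 2 `O=C(O)/C(S)=C/c1c[nH]c2cc(Cl)ccc12`: 100 nM
- compound 3 `O=C(O)/C(S)=C/c1ccccc1Cl`: 20700 nM

In an assay on isolated protein for inhibition of Calpain-1 catalytic subunit (Sus scrofa) (on this read-out higher numbers stand for weaker inhibition and lower numbers for stronger inhibition), compound 2 gives 100 nM, the second highest of the three numbers. Its nearest neighbour is compound 1, and the step from one to the other, a 1.1-fold higher number from compound 1 to compound 2 (0.05 log units; within the scatter), is within the scatter. Compound 3, which lacks the fused ring system of the others, stands furthest away with 20700 nM.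

Compound 4 `O=C(O)/C(S)=C/c1c[nH]c2cc(I)ccc12` is not yet measured. It differs from compound 2 by iodo in place of chloro on an aromatic carbon. Among the measured compounds shown here, the only measured step that bears on this change is the exchange of halogens at the same position between compound 1 and compound 2, a 1.1-fold higher number from compound 1 to compound 2 (0.05 log units; within the scatter), which lay within the scatter. On that basis no change beyond the scatter is expected in this assay for compound 4, with a slight lean towards a lower number. The expected step is a 1.3-fold lower number from compound 2 to compound 4 (0.10 log units; within the scatter), and the estimate for compound 4 is 80 nM, with a range from 35 nM to 200 nM.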

Compound 4, half-maximal inhibitory concentration: 300 nM
Compound 4: middle estimate off by 3.8-fold (0.57 log units), on the low side; measured number outside the range, above it.
By their numbers in this assay, from the lowest: compounds 1 and 2 (each within the scatter of the next); then compound 4; then compound 3.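

In this assay the halogens at this position are not fully interchangeable: the exchange of bromo for chloro stayed within the scatter, yet iodo brings a 3.0-fold higher number from compound 2 to compound 4 (0.48 log units; beyond the scatter) and a 3.3-fold higher number from compound 1 to compound 4 (0.52 log units; beyond the scatter) as well. This aromatic carbon therefore responds to which halogen it carries, and a single atom exchange here can move the number beyond the scatter, though only modestly. Nothing shown gives a reason for the step with iodo.

The compounds shown leave open how a fluoro group, or a group that is not a halogen such as a methoxy group or an amine, would read at this place. They also leave open whether iodo would bring a similar step on another aromatic carbon of the core.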